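The compounds below may be only part of what the source reports. "The series", "measured", "known", "first", "only" and "open" are said of these compounds alone.

Compound 1, `N#CC1=C(N)Oc2c(N)cc3nc4ccccc4nc3c2C12C(=O)N(Cc1cnnn1-c1ccc(F)cc1)c1ccccc12`, in a functional assay on A549 cells (Homo sapiens) for antiproliferative activity, read by MTT assay, with a stated time of 48 h (on this read-out lower numbers stand for stronger inhibition and higher numbers for weaker inhibition), gives > 50000 nM, which is a limit of the assay and not a number.
Compound 2, `N#CC1=C(N)Oc2c(N)cc3nc4ccccc4nc3c2C12C(=O)N(Cc1cnnn1-c1ccccc1Br)c1ccccc12`, in this assay gives 27400 nM.

Going by the values given here, compound 2 therefore holds the only actual number in this assay; the other value is a limit. As far as these compounds go, the step from compound 1 to compound 2 was an at least 1.8-fold lower number from compound 1 to compound 2 (0.26 log units; that floor lies within the scatter), with 2-bromophenyl taking the place of 4-fluorophenyl on an aromatic nitrogen; it starts from the limit of > 50000 nM in this assay, at which 1 of the 2 values shown sits, so its true size is unknown. Compound 3, `COc1ccc(-n2nncc2CN2C(=O)C3(C(C#N)=C(N)Oc4c(N)cc5nc6ccccc6nc5c43)c3ccccc32)cc1`, differs from compound 2 by 4-methoxyphenyl in place of 2-bromophenyl on an aromatic nitrogen. Among the compounds with values here, only that one measured step bears on this change, and because it rests on a limit (the limit of > 50000 nM in this assay, at which 1 of the 2 values shown sits) it offers little guidance. No step beyond the scatter is expected, and there is a real chance that compound 3 again reaches only the limit. Compound 3 is expected to give about 35000 nM, within a range from 12000 nM to 120000 nM. The expected step of a 1.3-fold higher number from compound 2 to compound 3 (0.11 log units; within the scatter) is thus small.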

Compound 3, half-maximal inhibitory concentration: > 50000 nM
Compound 3: a limit, no number (the forecaster's own chance of this, stated with the estimate: 40%); at least 1.4-fold (0.15 log units) between middle value and limit.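

In this assay compound 3 gives > 50000 nM, which is a limit and not a number. Placing 4-methoxyphenyl on the aromatic nitrogen in place of 2-bromophenyl gives an at least 1.8-fold higher number from compound 2 to compound 3 (0.26 log units; that floor lies within the scatter), so 4-methoxyphenyl joins 4-fluorophenyl at the limit and 2-bromophenyl remains the only group here with a number, although the printed floor does not establish a real gap. The step between compound 1 and compound 3, methoxy in place of fluoro on an aromatic carbon, cannot be read because both values are limits: the limit of > 50000 nM in this assay, at which 2 of the 3 values shown sit.

As far as these compounds go, whether the number for compound 2 depends on the bromine itself or on where it sits stays open, and 4-bromophenyl would separate the two. From the compounds shown here alone, how an unsubstituted phenyl or a benzyl group would behave at this position also remains unknown.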